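The compounds below may be only part of what the source reports. "The series", "measured", "known", "first", "only" and "open" are said of these compounds alone.

Measured in a functional assay on MCF7 cells (Homo sapiens) for cytotoxicity, read by MTT assay, with a stated time of 72 h; on this read-out lower numbers stand for stronger inhibition and higher numbers for weaker inhibition:
- Compound 1 `Cc1cc(=O)n(-c2ccccc2C(F)(F)F)nc1C(=O)Nc1ccc(Oc2ncnc3sccc23)cc1`: > 40000 nM (a limit)
- Compound 2 `Cc1cc(=O)n(-c2ccc(Br)cc2F)nc1C(=O)Nc1ccc(Oc2ncnc3sccc23)cc1`: 15200 nM
- Compound 3 `Cc1cc(=O)n(-c2cccc(F)c2)nc1C(=O)Nc1ccc(Oc2ncnc3sccc23)cc1`: 27200 nM

The value for compound 1 is a limit of this assay and not a number. Compound 3 gives 27200 nM, which lies within the scatter of compound 2 at 15200 nM.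

Compound 4 `Cc1cc(=O)n(-c2ccc(F)cc2)nc1C(=O)Nc1ccc(Oc2ncnc3sccc23)cc1` differs from compound 3 on an aromatic nitrogen: 4-fluorophenyl in place of 3-fluorophenyl on an aromatic nitrogen. Three measured changes of this aryl group bear on it: a 1.8-fold higher number from compound 2 to compound 3 (0.25 log units; within the scatter), an at least 1.4-fold lower number from compound 1 to compound 3 (0.16 log units; that floor lies within the scatter) and an at least 2.6-fold lower number from compound 1 to compound 2 (0.42 log units; beyond the scatter). Only the last goes beyond the scatter, so no step beyond the scatter is expected in this assay. The expected step is a 1.2-fold lower number from compound 3 to compound 4 (0.07 log units; within the scatter). The estimate for compound 4 is 23000 nM, with an expected range from 11000 nM to 40000 nM.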

Compound 4, half-maximal inhibitory concentration: 21000 nM
For compound 4 the middle estimate is 1.1-fold (0.04 log units) above the measured one, and the stated range covers the measured number.
By their numbers in this assay, from the lowest: compounds 2, 4 and 3 (each within the scatter of the next). At a limit, above all of these: compound 1.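

In this assay, 4-fluorophenyl in place of 3-fluorophenyl on this aromatic nitrogen gives a 1.3-fold lower number from compound 3 to compound 4 (0.11 log units; within the scatter), so moving the fluorine shows no effect that can be told from the scatter. 4-Fluorophenyl in place of 4-bromo-2-fluorophenyl gives a 1.4-fold higher number from compound 2 to compound 4 (0.14 log units; within the scatter), which does not set these two groups apart either. In place of 2-(trifluoromethyl)phenyl it gives an at least 1.9-fold lower number from compound 1 to compound 4 (0.27 log units; that floor lies within the scatter), and the starting value of that step is a limit and not a number.

As far as these compounds go, what an unsubstituted phenyl, or a phenyl carrying an amine or a carboxylic acid, would give at this position stays open.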